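Naphthalenyl for Chlorophenyl at the Ring Carbon of Compound 2

This account rests on a few compounds, and the source may have more. Where it says the series, first, only, none or still open, it means among the compounds named here.

Measured compounds:
compound 1, `O=C1N=C(c2ccc(Oc3ccccc3)cc2)S/C1=C\c1ccc(Oc2ccccc2)cc1`: 650 nM
compound 2, `O=C1N=C(c2ccc(Cl)cc2)S/C1=C\c1ccc(Oc2ccccc2)cc1`: 170 nM

Of the compounds shown here, two have been measured in an assay on cells for inhibition of Polyunsaturated fatty acid 5-lipoxygenase (Homo sapiens), read by HPLC, with stated times of 15 min and 10 min; on this read-out higher numbers stand for weaker inhibition and lower numbers for stronger inhibition. Compound 1 `O=C1N=C(c2ccc(Oc3ccccc3)cc2)S/C1=C\c1ccc(Oc2ccccc2)cc1` gives 650 nM, and compound 2 `O=C1N=C(c2ccc(Cl)cc2)S/C1=C\c1ccc(Oc2ccccc2)cc1` gives 170 nM. For the measured compounds named here, the one step between them, a 3.8-fold lower number from compound 1 to compound 2 (0.58 log units; beyond the scatter), is the only guide available, and it concerns the same carbon with a double bond to nitrogen that is changed here. Going by the values given here, compound 2 stands with the lowest of the two numbers, compound 1 being its only neighbour.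

Compound 3 `O=C1N=C(c2ccc3ccccc3c2)S/C1=C\c1ccc(Oc2ccccc2)cc1` has not yet been measured. It differs from compound 2 by naphthalen-2-yl in place of 4-chlorophenyl on a carbon with a double bond to nitrogen. Among the compounds with values here, no measured step covers naphthalen-2-yl itself; the step from compound 1 to compound 2 shows only that the larger phenoxy group gave a higher number than chloro at this carbon. Naphthalen-2-yl is therefore expected to move the number up again, though less far than phenoxy did, so the estimated step is a 1.9-fold higher number from compound 2 to compound 3 (0.27 log units; within the scatter). Compound 3 is accordingly expected to give about 320 nM in this assay, with a range from 110 nM to 950 nM.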

Compound 3, half-maximal inhibitory concentration: 480 nM
Compound 3: middle estimate off by 1.5-fold (0.18 log units), on the low side, within the range that was stated.
By their numbers in this assay, from the lowest: compound 2; then compounds 3 and 1 (each within the scatter of the next).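

In this assay, naphthalen-2-yl in place of 4-chlorophenyl on the carbon with a double bond to nitrogen gives a 2.8-fold higher number from compound 2 to compound 3 (0.45 log units; beyond the scatter) and leaves compound 2 with the lowest number of the three. Both groups tried in place of 4-chlorophenyl at this carbon therefore give a higher number, and compound 3 at 480 nM and compound 1 at 650 nM lie within the scatter of each other, so these two replacements cannot be told apart. Nothing available bears on the reason for this rise.

The compounds shown leave open whether the chlorine itself matters, which plain phenyl or 4-bromophenyl at this carbon would address. They also leave open how a group carrying an amine, such as 4-aminophenyl, or a carboxylic acid would behave here.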